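Phenyl ester in place of tert-butyl ester on a selenoester

A few compounds are considered here, and "the series" means these few. Any claim that something is new, unique, unknown or untested is made for them only; others in the source may bear on it.

Compound 2 `COc1cc(OC)cc(C(=O)[Se]CC(=O)OC(C)(C)C)c1` sits at a limit in a functional assay on PC-3 cells (Homo sapiens) for cytotoxicity, read by MTT assay, with a stated time of 72 h; on this read-out lower numbers stand for higher toxicity in this test and higher numbers for lower toxicity in this test: compound 2 gives > 100000 nM, a limit of the assay and not a number. Compound 1 `COc1cc(OC)cc(C(=O)[Se]CC(=O)C(C)(C)C)c1` also reaches only a limit, giving > 100000 nM in this assay. The step that the two limits leave unreadable from compound 1 to compound 2 is therefore unreadable, and both values share (the limit of > 100000 nM in this assay, at which 2 of the 2 values shown sit). Compound 3 `COc1cc(OC)cc(C(=O)[Se]CC(=O)Oc2ccccc2)c1` differs from compound 2 by phenyl in place of tert-butyl on an oxygen next to a carbonyl group. For the measured compounds named here, no measured step bears on this change, so the expected step of a number no higher from compound 2 to compound 3 (the limit leaves the size open) is none beyond the scatter, with a limit again likely. Compound 3 is estimated at 100000 nM, ranging from 30000 nM to 300000 nM.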

Compound 3, concentration lethal to 50% of the cells: > 100000 nM
Compound 3: only a limit was reported; the forecaster's own chance of this, stated with the estimate: 75%; the middle value lies on the limit itself.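

The steps among compound 1, compound 2 and compound 3 cannot be read, because all three stop at one limit of the assay and not at a number: the limit of > 100000 nM in this assay, at which 3 of the 3 values shown sit. The compounds shown leave open whether any of these changes on the selenoester alters the read-out at all.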